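Swapping nitro for trifluoromethyl on the benzyl thioether

The compounds below may be only part of what the source reports. "The series", "measured", "known", "first", "only" and "open" are said of these compounds alone.

Measured so far:
Compound 1, `OC[C@H]1O[C@@H](n2cnc3c(SCc4ccc(Br)cc4)ncnc32)[C@H](O)[C@@H]1O` — in an assay on isolated protein for inhibition of Equilibrative nucleoside transporter 1 (Homo sapiens) (a higher number here means a weaker inhibitor, a lower number a stronger inhibitor), compound 1 gives 11.5 nM.
Compound 2, `O=[N+]([O-])c1ccccc1CSc1ncnc2c1ncn2[C@@H]1O[C@H](CO)[C@@H](O)[C@H]1O` — in this assay compound 2 gives 115 nM.
Compound 3, `O=[N+]([O-])c1cccc(CSc2ncnc3c2ncn3[C@@H]2O[C@H](CO)[C@@H](O)[C@H]2O)c1` — in this assay compound 3 gives 1.78 nM.

Compound 3 holds the lowest number of the three. Its nearest neighbour is compound 1, and the step of a 6.5-fold lower number from compound 1 to compound 3 (0.81 log units; beyond the scatter) lies beyond the scatter; compound 2 sits furthest away, with the step of a 65-fold lower number from compound 2 to compound 3 (1.81 log units; beyond the scatter) being large. The remaining step, a 10-fold higher number from compound 1 to compound 2 (1.00 log units; beyond the scatter), shows that moving the group on the benzyl ring to another position also shifts the result by a modest amount.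

Compound 4, `OC[C@H]1O[C@@H](n2cnc3c(SCc4cccc(C(F)(F)F)c4)ncnc32)[C@H](O)[C@@H]1O`, keeps everything of compound 3 except one change: trifluoromethyl in place of nitro on an aromatic carbon. The position of the group is unchanged, so the three measured steps, which all vary the group or its position on that ring, only show that this part of the molecule governs the readout to a modest or large degree; none of them replaces nitro by trifluoromethyl, and none is a direct precedent.

Because compound 3 gives 1.78 nM and the substituent stays at the same position, compound 4 is expected to remain among the lower numbers. The estimate for compound 4 in this assay is 4 nM, with a range from 1.2 nM to 15 nM, meaning an expected step of a 2.2-fold higher number from compound 3 to compound 4 (0.35 log units; beyond the scatter), which is close to the scatter.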

Compound 4, inhibition constant: 19.1 nM
Compound 4: the middle estimate sits 4.8-fold (0.68 log units) below what was measured, and the stated range ends below it.
By their numbers in this assay, from the lowest: compound 3; then compounds 1 and 4 (each within the scatter of the next); then compound 2.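

The change from nitro to trifluoromethyl at this unchanged position shows that the identity of the group, and not only its place on the ring, governs the result in this assay, with an 11-fold higher number from compound 3 to compound 4 (1.03 log units; beyond the scatter). The trifluoromethyl compound keeps a clear margin over the 2-nitrophenyl compound, with a 6.0-fold lower number from compound 2 to compound 4 (0.78 log units; beyond the scatter), but it does not separate from the 4-bromophenyl compound, with a 1.7-fold higher number from compound 1 to compound 4 (0.22 log units; within the scatter), so 3-nitrophenyl alone stands clear of every other benzyl substituent shown here. The data offered here give no measured basis for explaining why nitro and trifluoromethyl differ at this position.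

On these data alone, it remains open whether other groups at this same place, such as a nitrile, an amine or a carboxylic acid, would match the number of compound 3 or fall nearer those of compound 1 and compound 4. Also open, as far as these compounds go, is whether moving trifluoromethyl to another position on the ring would shift the number as strongly as the same move does for nitro, which would tell whether the effect of position carries over from one group to the other.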